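Swapping One Aromatic Ring for Another: A Clearance Estimate

A few compounds are considered here, and "the series" means these few. Any claim that something is new, unique, unknown or untested is made for them only; others in the source may bear on it.

- compound 1 `CNC(=O)[C@@H]1CCCN1S(=O)(=O)c1ccc(Cl)c(COc2cccc3c(C(F)(F)F)cc(C)nc23)c1Cl`: 250 mL/min/kg
- compound 2 `CNC(=O)[C@@H]1CCCN1S(=O)(=O)c1ccc(Cl)c(COc2cccc3c(-c4nccn4C)cc(C)nc23)c1Cl`: 117 mL/min/kg

In an ADME assay on microsomes (Homo sapiens) for metabolic stability (a lower number here means slower removal, a higher number faster removal of the compound), compound 2 gives the lower of the two numbers, 117 mL/min/kg. Compound 3 `CNC(=O)[C@@H]1CCCN1S(=O)(=O)c1ccc(Cl)c(COc2cccc3c(-c4cccnc4)cc(C)nc23)c1Cl` has pyridin-3-yl in place of 1-methyl-1H-imidazol-2-yl, opposite the ring nitrogen: pyridin-3-yl in place of 1-methyl-1H-imidazol-2-yl on an aromatic carbon. Within the data shown here, only one measured step touches this carbon, a 2.1-fold lower number from compound 1 to compound 2 (0.33 log units; beyond the scatter), which is modest and replaced trifluoromethyl rather than one aromatic ring with another. It gives only weak guidance, so no change beyond the scatter is expected, and the expected step is a 1.1-fold higher number from compound 2 to compound 3 (0.05 log units; within the scatter). Compound 3 is estimated at 130 mL/min/kg, with an expected range of 70 mL/min/kg to 230 mL/min/kg.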

Compound 3, clearance: 233 mL/min/kg
Estimate against measurement, compound 3: 1.8-fold (0.25 log units) below, outside the stated range (above it).
By their numbers in this assay, from the lowest: compounds 2, 3 and 1 (each within the scatter of the next, the first and the last beyond it).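

On the aromatic carbon opposite the ring nitrogen, this assay now shows a 2.0-fold higher number from compound 2 to compound 3 (0.30 log units; within the scatter) and a 1.1-fold lower number from compound 1 to compound 3 (0.03 log units; within the scatter). Both steps lie within the scatter, so pyridin-3-yl cannot be separated from either 1-methyl-1H-imidazol-2-yl or trifluoromethyl, although those two groups do differ beyond the scatter, as a 2.1-fold lower number from compound 1 to compound 2 (0.33 log units; beyond the scatter) shows. Nothing available explains this result.

Still open, from the compounds shown here alone, is whether a pyridin-2-yl or pyridin-4-yl ring would read like pyridin-3-yl here. An amine or a carboxylic acid on this carbon also remains untested among the compounds shown.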